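Working Notes: One Methoxy Step Carried Across the Series

This account rests on a few compounds, and the source may have more. Where it says the series, first, only, none or still open, it means among the compounds named here.

Measured so far in a functional assay on UACC-62 cells (Homo sapiens) for cytotoxicity, read by sulforhodamine B assay, with a stated time of 48 h, tested at 0.01 uM; on this read-out higher numbers stand for a weaker effect at the one concentration tested and lower numbers for a stronger effect:
Compound 1 `COc1ccc(-c2cc(/C=C/C(=O)c3ccc(N)cc3)[nH]n2)cc1`: 96%
Compound 2 `COc1ccc(C(=O)/C=C/c2cc(-c3cc(OC)c(OC)c(OC)c3)n[nH]2)cc1OC`: 98%
Compound 3 `COc1ccc(-c2cc(/C=C/C(=O)c3ccc(N)cc3)[nH]n2)cc1OC`: 99%

Compound 3 differs from compound 1 by methoxy in place of hydrogen on an aromatic carbon, and the consequence in this assay is a number 3 percentage points higher from compound 1 to compound 3 (within the scatter). Compound 2 and compound 1 differ in more than one place; the difference between the two cores is not broken down here, and what the numbers show is that compound 1 gives 96% while compound 2 gives 98%, the two lying within the scatter of each other. Compound 2 and compound 3 are likewise within the scatter of each other.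

Compound 4 `COc1cc(C(=O)/C=C/c2cc(-c3cc(OC)c(OC)c(OC)c3)n[nH]2)cc(OC)c1OC` is not yet measured in this assay. It differs from compound 2 by methoxy in place of hydrogen on an aromatic carbon. Among the compounds with values here, this is the same kind of change as the one from compound 1 to compound 3, though the surroundings are not identical: in compound 4 the entering methoxy is also meta to a methoxy group, which is not so in compound 3.

For compound 4 the expected step is no change at the digits printed from compound 2 to compound 4 (within the scatter), set beside the measured a number 3 percentage points higher from compound 1 to compound 3 (within the scatter), because the earlier step was within the scatter and because compound 2 already gives 98%, leaving little room for the number to move upward. Compound 4 is therefore estimated at 98%, with a range from 89% to 105%.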

Compound 4, a percentage reported as activity, at one concentration (the size of the read-out at that concentration, not a potency): 97%
Compound 4: middle estimate off by 1 percentage points, on the high side; measured number inside the range.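

Methoxy in place of hydrogen on an aromatic carbon gives a number 1 percentage points lower from compound 2 to compound 4 (within the scatter) in this assay, so on this second core the change again leaves the read-out within the usual scatter of repeated measurements. Set beside the earlier step, the two results do not differ, and within this pair of cores the change carries over without a detectable difference in its outcome: the same change on two cores in this assay, a number 3 percentage points higher (within the scatter) from compound 1 to compound 3 and a number 1 percentage points lower (within the scatter) from compound 2 to compound 4, 4 percentage points apart, within the scatter of two such steps. This does not show that the change is without consequence on either core, since a read-out at one concentration is not a potency and says nothing about how these compounds compare at other concentrations; nor do two steps establish a rule for cores beyond those of compound 1 and compound 2.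

On these data alone, the groups entering at this kind of place on the aromatic ring are limited here to methoxy, so whether ethoxy, a longer alkoxy chain, a chlorine atom or a carboxylic acid would fall within the scatter in the same way remains open. Also open, as far as these compounds go, is how any of these four compounds behaves at concentrations other than the one tested.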